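The source may report more compounds than this note shows. Statements on the series, on what has been measured and on what is new or still open speak of the compounds shown alone.

Measured compounds in a functional assay on isolated protein for inhibition of Glucose-dependent insulinotropic receptor (Rattus norvegicus), read by HTRF and cAMP accumulation; on this read-out higher numbers stand for an effect only at larger amounts of compound and lower numbers for an effect already at smaller amounts:

compound 1 `Cc1nc(S(C)(=O)=O)ccc1Oc1ncnc(OC2CCN(C(=O)O[C@H](C)CF)CC2)c1F`: 1520 nM
compound 2 `Cc1nc(S(C)(=O)=O)ccc1Oc1ncnc(OC2CCN(C(=O)O[C@@H](C)CF)CC2)c1F`: 1680 nM
compound 3 `Cc1nc(S(C)(=O)=O)ccc1Oc1ncnc(OC2CCN(C(=O)O[C@@H](C)C(F)(F)F)CC2)c1F`: 109 nM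

Compound 3 stands lowest of the three numbers in this assay; the nearest is compound 1, then compound 2, both beyond the scatter. The steps of a 14-fold lower number from compound 1 to compound 3 (1.14 log units; beyond the scatter) and a 15-fold lower number from compound 2 to compound 3 (1.19 log units; beyond the scatter) are both large, while a 1.1-fold higher number from compound 1 to compound 2 (0.04 log units; within the scatter) is within the scatter, consistent with the fact that compounds 1 and 2 differ only in the configuration as drawn.

Compound 4 `CCC1(OC(=O)N2CCC(Oc3ncnc(Oc4ccc(S(C)(=O)=O)nc4C)c3F)CC2)CC1` is not yet measured. The change from compound 3 is 1-ethylcyclopropyl in place of 1-(trifluoromethyl)ethyl on an oxygen next to a carbonyl group. For the measured compounds named here, no measured pair covers this change: the only step at this position is the trifluoromethyl for fluoromethyl exchange, which moved the number by a 14-fold lower number from compound 1 to compound 3 (1.14 log units; beyond the scatter). Compound 4 carries no fluorine on the carbamate side chain and brings a three-membered ring instead, so the measured steps give no direct guide; the estimate for compound 4 is therefore wide and placed between compound 3 and compounds 1 and 2, expected as a 3.7-fold higher number from compound 3 to compound 4 (0.56 log units; beyond the scatter). Compound 4 is estimated at 400 nM, with a range from 100 nM to 1600 nM.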

Compound 4, half-maximal effective concentration: 333 nM
Compound 4: middle estimate off by 1.2-fold (0.08 log units), on the high side; the range from low to high includes it.
By their numbers in this assay, from the lowest: compound 3; then compound 4; then compounds 1 and 2 (each within the scatter of the next).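

In this assay, a side chain without fluorine and with a three-membered ring still gives a lower number than the monofluorinated chains on an oxygen next to a carbonyl group: a 4.6-fold lower number from compound 1 to compound 4 (0.66 log units; beyond the scatter) and a 5.0-fold lower number from compound 2 to compound 4 (0.70 log units; beyond the scatter). Fluorine on this side chain is thus not needed to get below compounds 1 and 2, although 1-(trifluoromethyl)ethyl keeps the lowest number of the four: a 3.1-fold higher number from compound 3 to compound 4 (0.49 log units; beyond the scatter). Nothing available bears on the reason for these steps.

The compounds shown do not separate the contribution of the ring from that of the ethyl group, which a plain cyclopropyl or a tert-butyl group at this place would address. Going by these compounds, how a side chain carrying an amine or a carboxylic acid would read here also stays open.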